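This account rests on a few compounds, and the source may have more. Where it says the series, first, only, none or still open, it means among the compounds named here.

Series notes. Compound 1 `O=c1nc2ccc(Br)cn2cc1Cc1ccc(Cl)cc1` is tested in a functional assay on HeLa cells (Homo sapiens) for cytotoxicity, read by MTT assay, with a stated time of 24 h (on this read-out lower numbers stand for stronger inhibition and higher numbers for weaker inhibition), and gives only a limit, > 1000000 nM. Compound 2 `Nc1cc(Br)cn2cc(Cc3ccc(F)cc3C(F)(F)F)c(=O)nc12` likewise sits at a limit in this assay, > 1000000 nM. Compound 3 `Nc1cccn2cc(Cc3ccccc3)c(=O)nc12` gives a measured value in this assay of 112000 nM. Going by the values given here, compound 1 thus stands at the limit of > 1000000 nM in this assay, at which 2 of the 3 values shown sit; no numerical value exists for it, and no pair of measured compounds differs in a single place, so no step size can be read from the series. Compound 4 `COc1ccc(Cc2cn3cc(Br)ccc3nc2=O)cc1` is not yet measured. methoxy in place of chloro on an aromatic carbon Without a measured step to lean on, the expected change is a number no higher from compound 1 to compound 4 (the limit leaves the size open), none beyond the scatter, with a further limit the likely outcome. Compound 4 is therefore estimated at 1000000 nM, in the range 300000 nM to 3000000 nM.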

Compound 4, half-maximal inhibitory concentration: 928000 nM
Estimate against measurement, compound 4: 1.1-fold (0.03 log units) above, within the range that was stated.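

With methoxy in place of chloro on an aromatic carbon para to a large group, the series now has a pair that differs in one place, and in this assay the change gives an at least 1.0-fold lower number from compound 1 to compound 4 (0.03 log units; that floor lies within the scatter). On these data alone, compound 1 gives only a limit, > 1000000 nM, so the true size of this step stays unknown. The number for compound 4 stays close to a limit shared by other compounds: the limit of > 1000000 nM in this assay, at which 2 of the 4 values shown sit.

As far as these compounds go, whether an amine or a carboxylic acid at this position would give a step beyond the scatter stays open. Steps at other places on the core cannot be read.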